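Chlorothiophene replaces thiophene on the hydrazide carbonyl

The source may report more compounds than this note shows. Statements on the series, on what has been measured and on what is new or still open speak of the compounds shown alone.

The series shares one core, shown for compound 1 as `CCOC(=O)C1=C(C)NC(C)=C(C(=O)OCC)C1c1ccc(OCC(=O)NNC(=O)c2ccc(C)cc2)cc1`, which in a functional assay on the whole organism (strain Wistar) for inhibition, with Rattus norvegicus as the target, read by paw edema, with stated times of 30 min and 3 h, at a dose of 20 mg/kg (a lower number here means less inhibition, a higher number more inhibition at the dose given (going by the name of the read-out)), gives compound 1 47.3%. Compound 2, `CCOC(=O)C1=C(C)NC(C)=C(C(=O)OCC)C1c1ccc(OCC(=O)NNC(=O)c2cccs2)cc1`, carries thiophen-2-yl on the carbonyl carbon instead, and in this assay compound 2 gives 61.1%. Among the measured compounds shown here, the only step measured so far, a number 13.8 percentage points higher from compound 1 to compound 2 (beyond the scatter), lies beyond the scatter. On these two numbers compound 2 stands highest, with compound 1 as its nearest neighbour below it.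

Compound 3, `CCOC(=O)C1=C(C)NC(C)=C(C(=O)OCC)C1c1ccc(OCC(=O)NNC(=O)c2ccsc2Cl)cc1`, is the unmeasured member. The change from compound 2 is 2-chlorothiophen-3-yl in place of thiophen-2-yl on a carbonyl carbon. For the measured compounds named here, the one measured step bears on the same carbonyl carbon, yet it exchanged a whole aromatic ring; here the ring stays a thiophene, changes its point of attachment and gains a chlorine. Going by the values given here, no measured step speaks to a chlorine or to the attachment point, so the expectation rests on the ring staying similar.

Compound 3 is therefore expected to show a step of a number 4.1 percentage points lower from compound 2 to compound 3 (within the scatter), not beyond the scatter. The estimate for compound 3 in this assay is 57%, between 42% and 72%.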

Compound 3, a percentage reported as inhibition, in the whole organism at one dose (the size of the read-out at that dose, not a potency): 53.3%
Beside the measured number, compound 3's estimate is 3.7 percentage points above it; measured number inside the range.
By their numbers in this assay, from the lowest: compounds 1, 3 and 2 (each within the scatter of the next, the first and the last beyond it).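

In this assay, the move on the carbonyl carbon from thiophen-2-yl to 2-chlorothiophen-3-yl, which keeps the five-membered aromatic ring but adds a chlorine and changes the attachment point, gives a number 7.8 percentage points lower from compound 2 to compound 3 (within the scatter). The earlier compounds shown here showed only an exchange of one aromatic ring for another at this place, and that step, a number 13.8 percentage points higher from compound 1 to compound 2 (beyond the scatter), lay beyond the scatter, whereas the new comparison with the same 4-methylphenyl starting point gives a number 6 percentage points higher from compound 1 to compound 3 (within the scatter), so the two thiophene compounds do not stand apart from 4-methylphenyl in the same way, and compound 3 cannot be separated by this read-out from either of the other two compounds. No measurement is available that would explain these differences or the lack of them.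

The chlorine and the attachment point changed together, so the compounds shown cannot assign any part of the step to either one, and a thiophen-3-yl without chlorine would be needed to separate them. They also leave open what a group of a different kind on the carbonyl carbon, such as a chain amine or a ring bearing a carboxylic acid, would do in this assay.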